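One Benzyl Swap on a Shared Core

The source may report more compounds than this note shows. Statements on the series, on what has been measured and on what is new or still open speak of the compounds shown alone.

Measured in a functional assay on Hs-578T cells (Homo sapiens) for inhibition, read by sulforhodamine B assay, with a stated time of 48 h; a lower number here means a stronger inhibitor of growth, a higher number a weaker inhibitor of growth:
- Compound 1, `CCOC(=O)[C@H](CCC(=O)O)NC(=O)c1ccc(CNc2nc3cc(N)cc(N)c3nc2-c2ccccc2)cc1`: for compound 1 the assay reports only a limit, < 100000 nM.
- Compound 2, `Nc1cc(N)c2nc(-c3ccccc3)c(NCc3ccc(Cl)c(Cl)c3)nc2c1`: compound 2 gives 5890 nM.
- Compound 3, `CCOC(=O)[C@H](CCC(=O)O)NC(=O)c1ccc(Oc2nc3cc(N)cc(N)c3nc2-c2ccccc2)cc1`: compound 3 gives 43700 nM.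

Of the two plain numbers, compound 2 holds the lower one; the number of compound 3 lies higher than that of compound 2 by a gap beyond the usual scatter. Compound 1 contributes a limit only, (the limit of < 100000 nM in this assay, at which 1 of the 3 values shown sits), and no number that could be ordered against the other two.

Compound 4, `COc1ccc(CNc2nc3cc(N)cc(N)c3nc2-c2ccccc2)cc1`, differs from compound 2 in a single place: 4-methoxyphenyl in place of 3,4-dichlorophenyl on a saturated chain carbon bound to a nitrogen on an aromatic ring. Within the data shown here, no pair of measured compounds shows this same exchange, so no measured step can be borrowed for it. The change keeps the same shape of group on the same chain carbon and alters only what the aromatic ring carries. The expectation is a moderate shift toward a higher number for compound 4, most likely somewhat beyond the scatter, though a result within it would not be surprising. The step from compound 2 expected here is a 2.5-fold higher number from compound 2 to compound 4 (0.41 log units; beyond the scatter). Compound 4 is estimated at 15000 nM in this assay, with a range from 5000 nM to 45000 nM.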

Compound 4, concentration for 50% growth inhibition: 26900 nM
Compound 4: middle estimate off by 1.8-fold (0.25 log units), on the low side; measured number inside the range.
By their numbers in this assay, from the lowest: compound 2; then compounds 4 and 3 (each within the scatter of the next).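

In this assay, 4-methoxyphenyl in place of 3,4-dichlorophenyl on a saturated chain carbon bound to a nitrogen on an aromatic ring gives a 4.6-fold higher number from compound 2 to compound 4 (0.66 log units; beyond the scatter), and this modest change is the only single-place step that can be read among the compounds shown. It shows that the number at this position depends on what the aromatic ring carries, even though both groups hold 8 heavy atoms on one six-membered aromatic ring of carbon only and differ in that the entering group has 1 hydrogen-bond acceptor and no chlorine. Nothing measured here bears on why the number moves in this direction.

The compounds shown leave open whether the step follows from losing the two chlorines or from gaining the methoxy group, a question that a plain benzyl group or a benzyl group carrying one chlorine could separate. As far as these compounds go, how an amine or a carboxylic acid on that same ring would read in this assay also stays open, as does the effect of a longer chain in place of the single chain carbon.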